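Amino in place of hydrogen on compound 3

This account rests on a few compounds, and the source may have more. Where it says the series, first, only, none or still open, it means among the compounds named here.

compound 1 `COc1ccc(-c2c[nH]c(=O)n2-c2cc(OC)c(OC)c(OC)c2)cc1`: > 50000 nM
compound 2 `COc1ccc(-c2c[nH]c(=O)n2-c2cc(OC)c(OC)c(OC)c2)cc1[N+](=O)[O-]`: > 50000 nM
compound 3 `COc1ccc(-c2cn(C(=O)Nc3cc(OC)c(OC)c(OC)c3)c(=O)n2-c2cc(OC)c(OC)c(OC)c2)cc1`: > 50000 nM
compound 4 `COc1ccc(-c2cn(C(=O)Nc3cc(OC)c(OC)c(OC)c3)c(=O)n2-c2cc(OC)c(OC)c(OC)c2)cc1N`: not yet measured

In a functional assay on A549 cells (Homo sapiens) for cytotoxicity, read by MTT assay, with a stated time of 48 h (on this read-out higher numbers stand for weaker inhibition and lower numbers for stronger inhibition), compound 3 gives > 50000 nM, which is a limit and not a number. Compound 1 and compound 2 offer no firmer footing: the limit of > 50000 nM in this assay, at which 3 of the 3 values shown sit.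

Compound 4 differs from compound 3 by a single change: amino in place of hydrogen on an aromatic carbon. The 4-methoxyphenyl becomes 3-amino-4-methoxyphenyl, with the amino group ortho to a methoxy group.

Going by the values given here, the only measured step that bears on this change is a step that the two limits leave unreadable from compound 1 to compound 2, which puts nitro in place of hydrogen on an aromatic carbon. It supplies no size or direction to carry over, and compound 3 offers only a limit as a starting point. In this assay, among the compounds with values here, no step of defined size is therefore expected, although a readable value on the stronger side remains possible.

The expected change is an at least 1.6-fold lower number from compound 3 to compound 4 (0.22 log units; that floor lies within the scatter). For compound 4 the estimate is 30000 nM, with an expected range from 4000 nM to 80000 nM.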

Compound 4, half-maximal inhibitory concentration: 11100 nM
Compound 4: middle estimate off by 2.7-fold (0.43 log units), on the high side; measured number inside the range.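

In this assay, amino in place of hydrogen, ortho to a methoxy group, brings an at least 4.5-fold lower number from compound 3 to compound 4 (0.65 log units; beyond the scatter), the only readable step among the compounds shown. The step from nitro in place of hydrogen cannot be read, so this position shows a measurable response only with amino, and only in compound 4. Compound 4 is also the only compound with a value that is a number rather than a limit: the limit of > 50000 nM in this assay, at which 3 of the 4 values shown sit.

On these data alone, whether amino would give a readable value on the smaller core of compound 1 remains open, and the true size of the step is unknown while compound 3 stands at a limit. Also open, as far as these compounds go, is how a hydroxyl or an acetamide at the same position would compare with amino.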